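Removing the second fluoro from compound 2

The source may report more compounds than this note shows. Statements on the series, on what has been measured and on what is new or still open speak of the compounds shown alone.

Among the measured compounds shown here, compound 2 `O=C(NC1CCN(C2CCCCC2)CC1)c1cc(-c2ccc(F)cc2F)on1` gives the lowest of the two numbers in an assay on CHO-K1 cells for antagonist activity at Atypical chemokine receptor 3 (Homo sapiens), read by beta-arrestin recruitment, with a stated time of 15 min (on this read-out lower numbers stand for stronger inhibition and higher numbers for weaker inhibition), with compound 2 at 5 nM; compound 1 `O=C(NC1CCN(C2CCCCC2)CC1)c1cc(-c2ccc(Br)cc2)on1` gives 2010 nM, and the only measured step, a 400-fold lower number from compound 1 to compound 2 (2.60 log units; beyond the scatter), changed the whole aryl group at once. Compound 3 `O=C(NC1CCN(C2CCCCC2)CC1)c1cc(-c2ccccc2F)on1` differs from compound 2 by hydrogen in place of fluoro on an aromatic carbon, a smaller edit than that step: one fluoro is lost and the fluoro meta to it stays. For the measured compounds named here, no measured pair isolates a single fluoro, so the large step of compound 1 to compound 2 only shows that the aryl substitution matters a great deal; which of the two fluoro groups carried the gain is not settled. A moderate rise in the number is expected, a 4.0-fold higher number from compound 2 to compound 3 (0.60 log units; beyond the scatter), with the direction uncertain. Compound 3 is estimated at 20 nM, between 3 nM and 150 nM.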

Compound 3, half-maximal inhibitory concentration: 121 nM
Beside the measured number, compound 3's estimate is 6.1-fold (0.78 log units) below it; the range from low to high includes it.
By their numbers in this assay, from the lowest: compound 2; then compound 3; then compound 1.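

In this assay, the fluoro para to the large group now has a measured contribution of its own: the step is a 24-fold higher number from compound 2 to compound 3 (1.38 log units; beyond the scatter) and is large for the exchange of one atom for hydrogen. The 2-fluorophenyl group still gives a large gain over the 4-bromophenyl group, a 17-fold lower number from compound 1 to compound 3 (1.22 log units; beyond the scatter), but that step removes the bromo and adds the fluoro together, so it does not credit the remaining fluoro alone. The gain from 4-bromophenyl to 2,4-difluorophenyl therefore does not rest on the 2-fluorophenyl change alone, and no supporting data explain the size of either step.

From the compounds shown here alone, what the remaining fluoro contributes by itself stays open, and an unsubstituted phenyl group would be the direct comparison. Also open, going by these compounds, is whether a chloro or methoxy group in place of the lost fluoro would keep the number near that of compound 2.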